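The compounds below may be only part of what the source reports. "The series", "measured", "known", "first", "only" and "open" are said of these compounds alone.

Among the compounds with values here, in a functional assay on MGC-803 cells (Homo sapiens) for inhibition, read by MTT assay, with a stated time of 72 h (a lower number here means a stronger inhibitor, a higher number a weaker inhibitor), compound 1 (`CCc1ccc(NC(=O)C2CCN(C/C=C/c3ccccc3)CC2)cc1`) gives 11600 nM, the highest number of the three measured so far and so the weakest inhibitor among them. Compound 2 (`CC(C)c1ccc(NC(=O)C2CCN(C/C=C/c3ccccc3)CC2)cc1`) gives 5200 nM, and compound 3 (`CCCCCc1ccc(NC(=O)C2CCN(C/C=C/c3ccccc3)CC2)cc1`) gives 2550 nM.

Compound 4 (`COc1ccc(NC(=O)C2CCN(C/C=C/c3ccccc3)CC2)cc1`) is still unmeasured. It differs from compound 1 by one change: methoxy in place of ethyl on an aromatic carbon. The new group sits on an aromatic carbon, para to a large group.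

Within the data shown here, three measured steps bear on this change: a 2.2-fold lower number from compound 1 to compound 2 (0.35 log units; beyond the scatter), then a 4.5-fold lower number from compound 1 to compound 3 (0.66 log units; beyond the scatter), and a 2.0-fold lower number from compound 2 to compound 3 (0.31 log units; beyond the scatter). All three are modest, and in each the alkyl group becomes larger. None of these compounds carries methoxy, so the data offer no direct guide to this swap, and methoxy does not extend the alkyl group as those steps did.

In this assay, no step beyond the scatter is therefore expected, and the estimate is a 1.0-fold higher number from compound 1 to compound 4 (0.01 log units; within the scatter). The range is kept wide for that reason. For compound 4, the expected value is 12000 nM, with an estimated range from 5000 nM to 30000 nM.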

Compound 4, half-maximal inhibitory concentration: 58200 nM
Compound 4: the middle estimate sits 4.9-fold (0.69 log units) below what was measured, and the stated range ends below it.
By their numbers in this assay, from the lowest: compound 3; then compound 2; then compound 1; then compound 4.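

Ethyl and methoxy each hold 2 heavy atoms, so the heavy-atom count alone does not set the number at this place on the ring: in this assay, the swap gives a 5.0-fold higher number from compound 1 to compound 4 (0.70 log units; beyond the scatter). The gaps to the two larger alkyl groups are wider, with an 11-fold higher number from compound 2 to compound 4 (1.05 log units; beyond the scatter) and a 23-fold higher number from compound 3 to compound 4 (1.36 log units; beyond the scatter), which leaves compound 4 as the weakest inhibitor of the four. Nothing measured on these compounds accounts for this difference.

As far as these compounds go, whether the higher number follows the oxygen itself or methoxy as a whole stays open: ethoxy or a longer chain joined through oxygen would test that, while an amine or chlorine would show how groups of other kinds compare. From the compounds shown here alone, how far the numbers fall with an alkyl chain longer than pentyl also remains unknown.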